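Removing a hydroxymethyl from one alkyne arm

The source may hold more compounds than are shown below. What is called first, only, known or untested is meant among the compounds shown, and "the series" means these compounds.

Measured compounds:
compound 1 `OCC#CCSc1cnc2ccccc2c1SCC#CCO`: 42.2 ug/mL
compound 2 `C#CC[Se]c1c(SCC#CCO)cnc2ccccc12`: 6.8 ug/mL

In a functional assay on B16 cells (Mus musculus) for cytotoxicity, read by sulforhodamine B assay, with a stated time of 72 h (on this read-out lower numbers stand for stronger inhibition and higher numbers for weaker inhibition), compound 1 gives 42.2 ug/mL, the higher of the two numbers, while compound 2 gives 6.8 ug/mL. Among the measured compounds shown here, the one measured step, a 6.2-fold lower number from compound 1 to compound 2 (0.79 log units; beyond the scatter), exchanges the whole group on an aromatic carbon, not the terminus alone. Compound 3 `C#CCSc1cnc2ccccc2c1SCC#CCO` differs from compound 1 by hydrogen in place of hydroxymethyl on a triple-bonded carbon. That step shares only part of the earlier exchange, so a smaller shift toward a lower number is expected. Compound 3 is estimated at 20 ug/mL, in the range 7 ug/mL to 45 ug/mL, corresponding to the expected step of a 2.1-fold lower number from compound 1 to compound 3 (0.32 log units; beyond the scatter).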

Compound 3, concentration for 50% inhibition: 54.7 ug/mL
Compound 3: the middle estimate sits 2.7-fold (0.44 log units) below what was measured; measured number outside the range, above it.
By their numbers in this assay, from the lowest: compound 2; then compounds 1 and 3 (each within the scatter of the next).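

In this assay, hydrogen in place of hydroxymethyl on this triple-bonded carbon gives a 1.3-fold higher number from compound 1 to compound 3 (0.11 log units; within the scatter), so this exchange alone does not separate compound 1 from compound 3. The low number of compound 2, 6.8 ug/mL, therefore cannot be read as the result of losing the hydroxymethyl alone. Nothing available explains why this change leaves the number within the scatter. As far as these compounds go, whether an amine or a longer chain on this triple-bonded carbon would shift the number remains open.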